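A Bromine Joins the Aniline Ring of Compound 3

The source may hold more compounds than are shown below. What is called first, only, known or untested is meant among the compounds shown, and "the series" means these compounds.

Of the compounds shown here, three sharing one core have been measured in a functional assay on KBVIN cells (Homo sapiens) for cytotoxicity, read by MTT assay, with a stated time of 72 h; a lower number here means that less compound is needed, a higher number that more compound is needed for the effect. In that setting compound 1 `COc1ccc(Nc2cc(-c3ccccc3)oc(=O)c2)cc1` gives 0.098 uM. Compound 2 `COc1ccc(Nc2cc(-c3ccc4ccccc4c3)oc(=O)c2)cc1` gives 0.13 uM. Compound 3 `O=c1cc(Nc2ccccc2)cc(-c2ccccc2)o1` gives 0.15 uM, the highest of the three numbers, though its steps to compound 2 and to compound 1 both lie within the scatter, so no order among the three can be claimed.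

Compound 4 `O=c1cc(Nc2ccc(Br)cc2)cc(-c2ccccc2)o1` has not yet been measured. It differs from compound 3 in one place: bromo in place of hydrogen on an aromatic carbon. The change sits on an aromatic carbon of a six-membered aromatic ring of carbon only, para to a large group.

Among the compounds with values here, one measured step bears on this position. a 1.5-fold higher number from compound 1 to compound 3 (0.18 log units; within the scatter) — this is the only step touching the same aromatic carbon, and it stayed within the scatter. With methoxy and hydrogen at that carbon giving numbers that cannot be told apart, there is no ground to expect bromo to move the number beyond the scatter either. The expected step is therefore no change at the digits printed from compound 3 to compound 4 (within the scatter), essentially none beyond the scatter. For compound 4 the estimate in this assay is 0.15 uM, with a range from 0.06 uM to 0.4 uM.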

Compound 4, concentration for half-maximal effect: 0.24 uM
Compound 4: middle estimate off by 1.6-fold (0.20 log units), on the low side, within the range that was stated.
By their numbers in this assay, from the lowest: compounds 1, 2, 3 and 4 (each within the scatter of the next, the first and the last beyond it).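

In this assay, bromo in place of hydrogen gives a 1.6-fold higher number from compound 3 to compound 4 (0.20 log units; within the scatter), so this aromatic carbon now carries a third group, and bromo cannot be told apart from hydrogen there. Within the data shown here, what the earlier compounds did not show comes from the other comparison at the same carbon: bromo in place of methoxy gives a 2.4-fold higher number from compound 1 to compound 4 (0.39 log units; beyond the scatter), the first step at this position to pass beyond the scatter, although it remains modest and compound 3, with hydrogen, stays within the scatter of both compound 1 and compound 4. The position is therefore not wholly indifferent to its substituent, but no measurement shown here accounts for this difference.

As far as these compounds go, it remains open whether a group of another kind at this carbon, such as an amine or a carboxylic acid, would move the number further than bromo or methoxy has. It is equally unknown whether bromo in place of methoxy would give a similar step on the scaffold of compound 2, or whether the step seen here holds only with the phenyl group of compound 1 and compound 4.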